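Swapping an aryl substituent on a shared core

The source may report more compounds than this note shows. Statements on the series, on what has been measured and on what is new or still open speak of the compounds shown alone.

Measured compounds:
compound 1: `CN(C)CCCCN(C(=O)O)c1ccccc1Cn1nc(-c2ccc(F)cc2)c2ccccc2c1=O` — 48500 nM
compound 2: `COc1ccc(-c2nn(Cc3ccc(NC(=O)OCCCCN(C)C)cc3)c(=O)c3ccccc23)cc1` — 20300 nM

In an ADME assay on Huh-7 cells (Homo sapiens) for cytotoxicity, read by MTT assay, with a stated time of 48 h (on this read-out lower numbers stand for higher toxicity in this test and higher numbers for lower toxicity in this test), compound 1 gives 48500 nM and compound 2 gives 20300 nM. Of these two numbers, compound 2 stands lowest; the nearest, compound 1, has the higher number, and the gap between them lies beyond the usual scatter. The two compounds differ in more than one place, so their two values can only be set side by side, not traced to a single change.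

Compound 3, `CN(C)CCCCOC(=O)Nc1ccc(Cn2nc(-c3cccc(C(F)(F)F)c3)c3ccccc3c2=O)cc1`, has not yet been measured in this assay. It differs from compound 2 in one change: 3-(trifluoromethyl)phenyl in place of 4-methoxyphenyl on an aromatic carbon, sitting on an aromatic carbon of a six-membered aromatic ring with 2 nitrogen, part of a fused or bridged system of two rings. Among the compounds with values here, no pair of measured compounds shows this kind of change, so nothing here says how large a step it brings. Compound 3 is expected to show a 1.1-fold lower number from compound 2 to compound 3 (0.05 log units; within the scatter), a step likely within the scatter or a little toward a lower number. The estimate for compound 3 in this assay is 18000 nM, within a range from 7000 nM to 45000 nM.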

Compound 3, half-maximal cytotoxic concentration: 11600 nM
Estimate against measurement, compound 3: 1.6-fold (0.19 log units) above; the measured number falls inside the stated range.
By their numbers in this assay, from the lowest: compounds 3 and 2 (each within the scatter of the next); then compound 1.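

In this assay, putting 3-(trifluoromethyl)phenyl in place of 4-methoxyphenyl gives a 1.8-fold lower number from compound 2 to compound 3 (0.24 log units; within the scatter), so this single swap cannot be told apart from the normal variation between repeated measurements. Compound 1 and compound 2 differ in more than one place and could say nothing about this position alone, whereas this pair shows that these two aryl groups, on an aromatic carbon of the six-membered aromatic ring with 2 nitrogen, give readings that lie within the scatter of each other. No measurement shown here offers a reason for the size of this step.

Within the data shown here, with only this one swap to read at this position, it stays open whether an aryl ring carrying an amine or a carboxylic acid, or a longer alkyl chain in place of the ring, would give a step beyond the scatter. On these data alone, it is also open whether the same swap would give a similar step in a compound with its side chain arranged as in compound 1.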